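Trimming the Sulfonyl Substituent of Compound 2

The compounds below may be only part of what the source reports. "The series", "measured", "known", "first", "only" and "open" are said of these compounds alone.

Measured so far, in an assay on CHO cells for displacement of a labelled ligand from prostaglandin D2 receptor 2 (Homo sapiens), read by scintillation counting; on this read-out lower numbers stand for stronger inhibition and higher numbers for weaker inhibition:
compound 1 `O=C(O)COc1ccccc1C#Cc1ccccc1Cl` gives 747 nM
compound 2 `O=C(O)COc1ccc(Cl)cc1C#Cc1cncc(S(=O)(=O)N2CCOCC2)c1` gives 41 nM
compound 3 `O=C(O)COc1ccc(Cl)cc1C#Cc1ccc2c(c1)S(=O)(=O)CC2` gives 23 nM

All three share a phenoxyacetic acid joined through an alkyne to a second aromatic ring. Compound 2 sits second highest of the three numbers in this assay. Its nearest neighbour is compound 3, whose lower number lies within the scatter, so the two cannot be told apart. Among the compounds with values here, its furthest neighbour is compound 1, whose much higher number lies well beyond the scatter; compound 1 is the one compound without a sulfonyl group.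

Compound 4 `CS(=O)(=O)c1cncc(C#Cc2cc(Cl)ccc2OCC(=O)O)c1` has not yet been measured. It differs from compound 2 in one place: methyl in place of morpholin-4-yl on a sulfonyl sulfur. The sulfonyl itself stays.

Within the data shown here, no pair of measured compounds differs in exactly this way, so the size of the step is a guess. Since compound 2 and compound 3 give close numbers in this assay despite differing in what surrounds their sulfonyl, a small step, none beyond the scatter, is expected here. Compound 4 is estimated at 50 nM, between 15 nM and 160 nM, a step of a 1.2-fold higher number from compound 2 to compound 4 (0.09 log units; within the scatter) expected.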

Compound 4, inhibition constant: 60 nM
Compound 4: the middle estimate sits 1.2-fold (0.08 log units) below what was measured; measured number inside the range.
By their numbers in this assay, from the lowest: compounds 3, 2 and 4 (each within the scatter of the next, the first and the last beyond it); then compound 1.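

The swap of morpholin-4-yl for methyl on a sulfonyl sulfur reads as a 1.5-fold higher number from compound 2 to compound 4 (0.17 log units; within the scatter), so compound 2 and compound 4 cannot be told apart in this assay. At this position, then, a single carbon on the sulfonyl sulfur does as well as the whole six-membered ring, and the ring's nitrogen and oxygen are not needed for a number of this size. Nothing measured here says why the step is so small.

From the compounds shown here alone, how a larger or charged group would fare on the same sulfur remains open, for example a longer chain such as n-butyl or a primary amine. Whether the sulfonyl itself matters is also unsettled, as no pair shown differs by that group alone, and a carbonyl in its place would test it.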